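This account rests on a few compounds, and the source may have more. Where it says the series, first, only, none or still open, it means among the compounds named here.

Measured compounds:
compound 1 `COc1ccc(Cn2ccc3nc(-c4ccccc4)nc-3c2)cc1` gives > 100000 nM
compound 2 `c1ccc(-c2ccc(Cn3ccc4nc(-c5ccccc5)nc-4c3)cc2)cc1` gives 18000 nM
compound 3 `FC(F)(F)Oc1ccc(Cn2ccc3nc(-c4ccccc4)nc-3c2)cc1` gives 66000 nM

These three compounds share one core and differ only in the group carried on the saturated chain carbon bound to an aromatic nitrogen. In an ADME assay on MDBK cells (Bos taurus) for cytotoxicity (a lower number here means that less compound is tolerated, a higher number that more compound is tolerated), compound 1 gives only a limit, (the limit of > 100000 nM in this assay, at which 1 of the 3 values shown sits), so no exact number is known for it. Putting phenyl in place of methoxy brought an at least 5.5-fold lower number from compound 1 to compound 2 (0.74 log units; beyond the scatter), a clear drop in tolerated concentration. Putting trifluoromethyl on the oxygen in place of methyl brought an at least 1.5-fold lower number from compound 1 to compound 3 (0.18 log units; that floor lies within the scatter), and between those two variants the step was a 3.7-fold higher number from compound 2 to compound 3 (0.56 log units; beyond the scatter).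

Compound 4 `CCC(CC)Cn1ccc2nc(-c3ccccc3)nc-2c1` has not yet been measured. (pentan-3-yl in place of 4-methoxyphenyl on a saturated chain carbon bound to an aromatic nitrogen). Among the measured compounds shown here, none of the measured steps replaces the aromatic group with a chain that has no ring, so they bear on this change only loosely: the one clear drop came with an added phenyl ring (an at least 5.5-fold lower number from compound 1 to compound 2 (0.74 log units; beyond the scatter)), whereas the other change stayed within the scatter (an at least 1.5-fold lower number from compound 1 to compound 3 (0.18 log units; that floor lies within the scatter)). For compound 4 I therefore expect no step beyond the scatter, an at least 1.1-fold lower number from compound 1 to compound 4 (0.04 log units; that floor lies within the scatter). Compound 4 is estimated to give 90000 nM, within a range from 30000 nM to 300000 nM, quite possibly reported only as a limit.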

Compound 4, half-maximal cytotoxic concentration: > 100000 nM
Compound 4 gave a limit, no number (the forecaster's own chance of this, stated with the estimate: 60%); middle value at least 1.1-fold (0.04 log units) away from the limit.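

Among the compounds shown here, compound 1 and compound 4 both reach only a limit in this assay, so no step between them can be read: the limit of > 100000 nM in this assay, at which 2 of the 4 values shown sit. The compounds shown leave open how much compound is tolerated beyond that limit, and whether pentan-3-yl in place of 4-methoxyphenyl changes it at all.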